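A few compounds are considered here, and "the series" means these few. Any claim that something is new, unique, unknown or untested is made for them only; others in the source may bear on it.

Series notes, alkyl chain on the shared core, read in a functional assay on L1210 cells (Mus musculus); on this read-out higher numbers stand for weaker inhibition and lower numbers for stronger inhibition.

Compound 1 `CCc1cn([C@H]2C[C@@H]3OP(=O)(O)OC[C@H]3O2)c(=O)[nH]c1=O`: in this assay compound 1 gives > 500 ug/mL, a limit of the assay and not a number.
Compound 2 `CCCCCCc1cn([C@H]2C[C@@H]3OP(=O)(O)OC[C@H]3O2)c(=O)[nH]c1=O`: in this assay compound 2 gives > 500 ug/mL, again a limit.
Compound 3 `CCCc1cn([C@H]2C[C@@H]3OP(=O)(O)OC[C@H]3O2)c(=O)[nH]c1=O`: in this assay compound 3 gives > 500 ug/mL, again a limit.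

Where compound 3 stands: only a limit is known for it, and the two other values are limits as well (the limit of > 500 ug/mL in this assay, at which 3 of the 3 values shown sit). The steps a step that the two limits leave unreadable from compound 1 to compound 3, a step that the two limits leave unreadable from compound 2 to compound 3 and a step that the two limits leave unreadable from compound 1 to compound 2 therefore carry no readable size in either direction.

Compound 4 `CCCCc1cn([C@H]2C[C@@H]3OP(=O)(O)OC[C@H]3O2)c(=O)[nH]c1=O` differs from compound 3 by methyl in place of hydrogen on a saturated chain carbon, three bonds along the chain from an aromatic carbon. Every measured change of the same kind along this chain, whether methyl or butyl entering, left the value at the limit, so no step beyond the scatter is expected from compound 3 to compound 4, and compound 4 is expected to sit at the same limit. The estimate for compound 4 is 800 ug/mL, with a range of 400 ug/mL to 3000 ug/mL. The expected step is a step that the limit leaves unreadable from compound 3 to compound 4.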

Compound 4, concentration for 50% inhibition: 33.5 ug/mL
For compound 4 the middle estimate is 24-fold (1.38 log units) above the measured one, outside the stated range (below it).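

In this assay compound 4, with its butyl chain, is the only one of the four alkyl compounds to give a value that is a number. Methyl entering three bonds along the chain from an aromatic carbon therefore matters here, with an at least 14-fold lower number from compound 3 to compound 4 (1.17 log units; beyond the scatter). The response to chain length is not steady, with an at least 14-fold lower number from compound 1 to compound 4 (1.17 log units; beyond the scatter) and an at least 14-fold lower number from compound 2 to compound 4 (1.17 log units; beyond the scatter), so the longer hexyl chain of compound 2 goes against any rule that a longer chain gives stronger inhibition. The steps among compound 1, compound 2 and compound 3 cannot be read, and the steps to compound 4 are bounds only: the limit of > 500 ug/mL in this assay, at which 3 of the 4 values shown sit.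

As far as these compounds go, whether a pentyl chain keeps the value of compound 4 stays open. Also open, from the compounds shown here alone, is whether a branched isobutyl group, or a butyl chain ending in an amine or a carboxylic acid, would do the same.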